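From Methoxy to Hydroxy on an Aromatic Ring

A few compounds are considered here, and "the series" means these few. Any claim that something is new, unique, unknown or untested is made for them only; others in the source may bear on it.

Of the compounds shown here, three with a shared core have been measured in a functional assay on MDA-MB-435 cells (Homo sapiens) for inhibition, read by sulforhodamine B assay, with a stated time of 48 h; on this read-out higher numbers stand for weaker inhibition of growth and lower numbers for stronger inhibition of growth. Compound 1 `COc1cc(C)cc(-c2c(-c3ccnc(-c4ccc(N(C)C)cc4)c3)cnn2CC#N)c1` gives 22.6 nM in this assay. Compound 2 `COc1cc(C)cc(-c2nn(CC#N)cc2-c2ccnc(-c3ccc(N(C)C)cc3)c2)c1` gives 235 nM, and compound 3 `COc1cc(C)cc(-c2nn(CC#N)cc2-c2ccc(-c3cccc(C(C)=O)c3)nc2)c1` gives 3410 nM. Among these three numbers compound 2 stands second highest: its nearest neighbour is compound 1, whose number lies beyond the scatter on the lower side, and its furthest is compound 3, whose number lies beyond the scatter on the higher side.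

Compound 4 `Cc1cc(O)cc(-c2nn(CC#N)cc2-c2ccnc(-c3ccc(N(C)C)cc3)c2)c1` has not yet been measured. It differs from compound 2 in one place: hydrogen in place of methyl on an oxygen on an aromatic ring. Cut one bond further out, the same difference reads methoxy to hydroxy, or 3-methoxy-5-methylphenyl to 3-hydroxy-5-methylphenyl.

Going by the values given here, no pair among the measured compounds differs in this way, so there is no measured step to draw on. Without such a step, the expectation in this assay is a modest move, most likely toward a higher number, though one that may fall within the scatter. Compound 4 is accordingly estimated at 500 nM, within a range from 120 nM to 2000 nM. That estimate corresponds to an expected step of a 2.1-fold higher number from compound 2 to compound 4 (0.33 log units; beyond the scatter).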

Compound 4, concentration for 50% growth inhibition: 1010 nM
Estimate against measurement, compound 4: 2.0-fold (0.31 log units) below, within the range that was stated.
By their numbers in this assay, from the lowest: compound 1; then compound 2; then compound 4; then compound 3.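

Going by these compounds alone, compounds 1 to 3 all carry the methoxy group, so they said nothing about what this oxygen substituent contributes; this pair is the first direct reading of it. In this assay, hydrogen in place of methyl on an oxygen on an aromatic ring gives a 4.3-fold higher number from compound 2 to compound 4 (0.63 log units; beyond the scatter) and so weakens inhibition of growth, showing that the methyl on this oxygen is not dispensable in this series and that the free hydroxy is the less effective of the two groups here. Within the data shown here, nothing available explains this difference, and the single pair gives no cause for it.

The pair leaves open how far the trend runs at this place, for instance whether an ethoxy group, a longer alkoxy chain or an amine in place of the methoxy would give a lower or a higher number than the two groups compared here. Among these compounds, it also leaves open whether the change from methoxy to hydroxy would give a step of similar size on the core of compound 1 or on that of compound 3, where no such pair is available for comparison.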